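From 1H-indazol-5-yl to 1-methyl-1H-indol-5-yl on a shared core

This account rests on a few compounds, and the source may have more. Where it says the series, first, only, none or still open, it means among the compounds named here.

In a functional assay on DU-145 cells (Homo sapiens) for inhibition, read by trypan blue exclusion, with a stated time of 72 h (a higher number here means a weaker inhibitor, a lower number a stronger inhibitor), three compounds with one shared core differ only in the group on a nitrogen on an aromatic ring. Compound 1 (`Cn1c(=O)c(S(=O)(=O)c2ccc(F)cc2F)cc2cnc(Nc3cccc4[nH]ccc34)nc21`), carrying 1H-indol-4-yl, gives 750 nM and compound 2 (`Cn1c(=O)c(S(=O)(=O)c2ccc(F)cc2F)cc2cnc(Nc3ccc4sccc4c3)nc21`), carrying 1-benzothiophen-5-yl, gives 500 nM in the same test. That is a 1.5-fold lower number from compound 1 to compound 2 (0.18 log units; within the scatter) and no real separation. Compound 3 (`Cn1c(=O)c(S(=O)(=O)c2ccc(F)cc2F)cc2cnc(Nc3ccc4[nH]ncc4c3)nc21`), carrying 1H-indazol-5-yl, stands highest at 30000 nM as the weakest inhibitor of the three. Compound 4 (`Cn1ccc2cc(Nc3ncc4cc(S(=O)(=O)c5ccc(F)cc5F)c(=O)n(C)c4n3)ccc21`) differs from it by 1-methyl-1H-indol-5-yl in place of 1H-indazol-5-yl on a nitrogen on an aromatic ring and nothing else. The steps bearing on this change are a 40-fold higher number from compound 1 to compound 3 (1.60 log units; beyond the scatter) and a 60-fold higher number from compound 2 to compound 3 (1.78 log units; beyond the scatter) and both are large, each arriving at 1H-indazol-5-yl from another group. Neither tests 1-methyl-1H-indol-5-yl itself, so the expectation stays loose. A large step in the opposite direction is expected, estimated as a 30-fold lower number from compound 3 to compound 4 (1.48 log units; beyond the scatter) in this assay toward a stronger inhibitor. For compound 4 the expected value is 1000 nM within an estimated range of 200 nM to 8000 nM for this measurement.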

Compound 4, half-maximal inhibitory concentration: 750 nM
Compound 4: the middle estimate sits 1.3-fold (0.12 log units) above what was measured; measured number inside the range.
By their numbers in this assay, from the lowest: compounds 2, 1 and 4 (each within the scatter of the next); then compound 3.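

In this assay, the change gives a 40-fold lower number from compound 3 to compound 4 (1.60 log units; beyond the scatter) and shows that the high number of compound 3 goes with 1H-indazol-5-yl and not with the shared core. The entering 1-methyl-1H-indol-5-yl joins the other groups at this place on a nitrogen on an aromatic ring, with a 1.5-fold higher number from compound 2 to compound 4 (0.18 log units; within the scatter) and no change at the digits printed from compound 1 to compound 4 (within the scatter), so compound 3 alone stands apart among the four. Nothing given here accounts for that gap.

This single step replaces a ring nitrogen with carbon, adds a methyl and goes from one hydrogen-bond donor to none, and the compounds shown do not separate these differences. Also open, from the compounds shown here alone, is what 1H-indol-5-yl or 1-methyl-1H-indazol-5-yl would give, and whether an amine or a carboxylic acid on the entering group would be tolerated.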